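Changing the Aryl Group on the Amine Side Chain

The source may hold more compounds than are shown below. What is called first, only, known or untested is meant among the compounds shown, and "the series" means these compounds.

Compound 1 `Nc1cc(N)c2nc(-c3ccccc3)c(Oc3ccc(Cl)c(Cl)c3)nc2c1`: < 100000 nM
Compound 2 `Nc1cc(N)c2nc(-c3ccccc3)c(NCc3ccc(Cl)c(Cl)c3)nc2c1`: 95500 nM
Compound 3 `COc1ccc(CNc2nc3cc(N)cc(N)c3nc2-c2ccccc2)cc1OC`: 64600 nM

Of the compounds shown here, three sharing one core have been tested in a functional assay on NCI-H226 cells (Homo sapiens) for inhibition, read by sulforhodamine B assay, with a stated time of 48 h; on this read-out lower numbers stand for higher toxicity in this test and higher numbers for lower toxicity in this test. The entry for compound 1, < 100000 nM, is a limit of the test rather than a number. Compound 2 gives 95500 nM in this assay. Compound 3 gives 64600 nM in this assay, and the difference between these two is a 1.5-fold lower number from compound 2 to compound 3 (0.17 log units; within the scatter), so compound 2 and compound 3 cannot be told apart on these numbers.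

Compound 4 `Nc1cc(N)c2nc(-c3ccccc3)c(NCc3ccc(F)cc3)nc2c1` has not yet been measured. It differs from compound 3 in one place: 4-fluorophenyl in place of 3,4-dimethoxyphenyl on a saturated chain carbon bound to a nitrogen on an aromatic ring. Going by the values given here, the only measured step that bears on this change is the one from compound 2 to compound 3, where the group on the same saturated chain carbon was exchanged and the numbers stayed within the scatter. By that precedent the step to compound 4 is expected to be small as well, a 1.2-fold higher number from compound 3 to compound 4 (0.06 log units; within the scatter), with no clear direction. Compound 4 is therefore estimated at 75000 nM in this assay, within a range from 30000 nM to 160000 nM.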

Compound 4, concentration lethal to 50% of the cells: < 100000 nM
Compound 4: a limit, no number (the forecaster's own chance of this, stated with the estimate: 30%); the middle value does not contradict the limit.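

Compound 4 gives only a limit of the test, not a number, so its steps from compound 1, compound 2 and compound 3 cannot be read: the limit of < 100000 nM in this assay, at which 2 of the 4 values shown sit. As far as these compounds go, whether 4-fluorophenyl gives a different number from 3,4-dimethoxyphenyl or 3,4-dichlorophenyl on this side chain stays open.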